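Replacing benzamido with 4-chlorophenyl: what to expect

The source may hold more compounds than are shown below. What is called first, only, known or untested is meant among the compounds shown, and "the series" means these compounds.

Compound 1 `O=C1Nc2ccc(S(=O)(=O)N3CCOCC3)cc2/C1=N/c1ccc(O)cc1`: 52700 nM
Compound 2 `N/N=C1\C(=O)Nc2ccc(S(=O)(=O)N3CCOCC3)cc21`: 46800 nM
Compound 3 `O=C1Nc2ccc(S(=O)(=O)N3CCOCC3)cc2/C1=N/NC(=O)c1ccccc1`: 414000 nM

All three values come from a functional assay on MCF7 cells (Homo sapiens) for cytotoxicity, read by sulforhodamine B assay, with a stated time of 24 h; on this read-out lower numbers stand for stronger inhibition and higher numbers for weaker inhibition. Compound 3 has the highest number of the three, which makes it the weakest here, and its steps to both of the others lie beyond the scatter. Compound 4 `O=C1Nc2ccc(S(=O)(=O)N3CCOCC3)cc2/C1=N/c1ccc(Cl)cc1` has not yet been measured. It keeps the shared core and changes one group: 4-chlorophenyl in place of benzamido on a double-bonded nitrogen.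

The closest guide is compound 1, which carries 4-hydroxyphenyl at that same place. The measured step of a 7.9-fold higher number from compound 1 to compound 3 (0.90 log units; beyond the scatter) shows what benzamido did there, and the step of an 8.8-fold higher number from compound 2 to compound 3 (0.95 log units; beyond the scatter) is of similar size. By contrast, the step of a 1.1-fold lower number from compound 1 to compound 2 (0.05 log units; within the scatter) stays within the scatter, so benzamido is the group that stands apart in this small set. Among the compounds with values here, no measured compound carries a chlorine, and three compounds are a thin basis, so the range must stay wide. Compound 4 loses the benzamido and should therefore land near compound 1 in this assay. The expected change is an 8.3-fold lower number from compound 3 to compound 4 (0.92 log units; beyond the scatter). For compound 4 the estimated value is 50000 nM, with an expected range of 15000 nM to 160000 nM.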

Compound 4, half-maximal inhibitory concentration: 44300 nM
Estimate against measurement, compound 4: 1.1-fold (0.05 log units) above; the measured number falls inside the stated range.
By their numbers in this assay, from the lowest: compounds 4, 2 and 1 (each within the scatter of the next); then compound 3.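

In this assay, 4-chlorophenyl in place of benzamido on the double-bonded nitrogen gives a 9.3-fold lower number from compound 3 to compound 4 (0.97 log units; beyond the scatter) and so brings compound 4 back among the other compounds, which shows that the aromatic ring carried by benzamido does not by itself set compound 3 apart: compound 4 also has a six-membered aromatic ring of carbon only at this place. At the far end of that ring, chloro in place of hydroxy gives a 1.2-fold lower number from compound 1 to compound 4 (0.08 log units; within the scatter) and 4-chlorophenyl in place of amino gives a 1.1-fold lower number from compound 2 to compound 4 (0.02 log units; within the scatter) with neither step beyond the scatter, so in this small set the position accepts all three of these groups with no readable difference, and only benzamido stands apart. Nothing measured here explains what makes benzamido different.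

The compounds shown leave open which part of benzamido matters, since no compound here carries an acetamido group, which keeps the carbonyl without the ring, or a benzylamino group, which keeps the ring without the carbonyl. They also leave open whether a phenyl ring bearing a carboxylic acid or a dimethylamino group would sit with compound 1, compound 2 and compound 4 or with compound 3.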